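Methoxy for Fluoro Across Two Related Cores

The source may hold more compounds than are shown below. What is called first, only, known or untested is meant among the compounds shown, and "the series" means these compounds.

The study compares two pairs of compounds in a functional assay on HBL-100 cells (Homo sapiens) for inhibition, read by sulforhodamine B assay, with a stated time of 48 h; a higher number here means a weaker inhibitor of growth, a lower number a stronger inhibitor of growth. Compound 1 `COC(=O)[C@@]1(C)CCC=C2[C@@H]1CC[C@@H](C)[C@]2(C)Cc1c[nH]c2ccc(F)cc12` gives 4800 nM in this assay. Compound 2 `COC(=O)[C@@]1(C)CCC=C2[C@@H]1CC[C@@H](C)[C@]2(C)Cc1c[nH]c2ccc(OC)cc12` differs from compound 1 by methoxy in place of fluoro on an aromatic carbon. In this assay compound 2 gives 2100 nM, and the step between the two is a 2.3-fold lower number from compound 1 to compound 2 (0.36 log units; beyond the scatter).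

Compound 3 `COC(=O)[C@@]1(C)CC[C@@H]2C3=C1CC[C@@H](C)[C@]3(C)C[C@@H]1c3cc(F)ccc3N[C@H]21` has the same atoms as compound 1, joined differently; the difference between the two cores is not broken down here. In this assay compound 3 gives 18000 nM, the highest number of the three measured compounds and well beyond the scatter from both compound 1 and compound 2.

Compound 4 `COC(=O)[C@@]1(C)CC[C@@H]2C3=C1CC[C@@H](C)[C@]3(C)C[C@@H]1c3cc(OC)ccc3N[C@H]21` has not yet been measured. It differs from compound 3 by methoxy in place of fluoro on an aromatic carbon. Among the measured compounds shown here, this is the same kind of change as the one from compound 1 to compound 2, though not the same: in compound 1 the aromatic carbon belongs to a six-membered aromatic ring of carbon only that is part of a fused or bridged system of two rings, whereas in compound 3 that ring is part of a fused or bridged system of five rings. For the measured compounds named here, since the step from compound 1 to compound 2 is the only measured instance of this change, the expectation for compound 4 rests on it alone. Going by the values given here, the estimated step is a 2.3-fold lower number from compound 3 to compound 4 (0.35 log units; beyond the scatter), which would place compound 4 at an expected 8000 nM in this assay, with a plausible range from 4000 nM to 18000 nM given that only one earlier step supports it.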

Compound 4, concentration for 50% growth inhibition: 15000 nM
The estimate for compound 4 lay 1.9-fold (0.27 log units) below the measured number, and the stated range covers the measured number.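

In this assay, the methoxy-for-fluoro change gave a 1.2-fold lower number from compound 3 to compound 4 (0.08 log units; within the scatter), so on this core the two groups cannot be told apart. Set beside the earlier step, the result gives no firm sign that the change behaves differently on the two cores: the same change on two cores in this assay, a 2.3-fold lower number (0.36 log units; beyond the scatter) from compound 1 to compound 2 and a 1.2-fold lower number (0.08 log units; within the scatter) from compound 3 to compound 4, 1.9-fold (0.28 log units) apart, within the scatter of two such steps. Among the compounds shown here, this does not show that the change carries over unchanged, however: with only two pairs, one step beyond the scatter and the other within it, a real difference between the cores remains possible, and so does a single small step shared by both.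

The compounds shown leave open how a chloro, hydroxyl or amine group on this aromatic carbon would read on either core, and whether any such group would give steps large enough to compare the two cores more clearly. They also leave open what a carboxylic acid or an amide in place of the methyl ester shared by all four compounds would do to the numbers in this assay.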